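This account rests on a few compounds, and the source may have more. Where it says the series, first, only, none or still open, it means among the compounds named here.

Measured so far in an assay on microsomes from intestine for inhibition of acyl-CoA:cholesterol acyltransferase (Oryctolagus cuniculus); on this read-out higher numbers stand for weaker inhibition and lower numbers for stronger inhibition:

compound 1, `O=C(NCC1(c2ccccc2)CCCCC1)Nc1ccccc1`: 2300 nM
compound 2, `O=C(NCC1(c2ccccc2)CCCCC1)Nc1ccc(Cl)cc1`: 2200 nM

In this assay, for the measured compounds named here, compound 2 gives 2200 nM, and its nearest neighbour is compound 1 with 2300 nM; the two numbers lie within the scatter of each other, the step being a 1.0-fold lower number from compound 1 to compound 2 (0.02 log units; within the scatter), with chloro in place of hydrogen on an aromatic carbon as the only change.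

The next compound in the series is compound 3, `CCOC(=O)c1ccc(NC(=O)NCC2(c3ccccc3)CCCCC2)cc1`. Against compound 2 the change is ethoxycarbonyl in place of chloro on an aromatic carbon, para to a large group. Going by the values given here, no measured step involves an ethoxycarbonyl; the only step available, a 1.0-fold lower number from compound 1 to compound 2 (0.02 log units; within the scatter), concerns the same aromatic carbon but a different group and was within the scatter. Nothing in the two measured compounds points to a shift beyond the scatter in either direction. For compound 3 the expected step is therefore a 1.1-fold higher number from compound 2 to compound 3 (0.06 log units; within the scatter). Compound 3 is estimated at 2500 nM, with an expected range from 800 nM to 8000 nM.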

Compound 3, half-maximal inhibitory concentration: 6100 nM
For compound 3 the middle estimate is 2.4-fold (0.39 log units) below the measured one; the range from low to high includes it.
By their numbers in this assay, from the lowest: compounds 2 and 1 (each within the scatter of the next); then compound 3.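

In this assay this aromatic carbon, para to a large group, does respond to what it carries: ethoxycarbonyl gives a step beyond the scatter against chloro (a 2.8-fold higher number from compound 2 to compound 3 (0.44 log units; beyond the scatter)) and against hydrogen (a 2.7-fold higher number from compound 1 to compound 3 (0.42 log units; beyond the scatter)), whereas chloro in place of hydrogen stayed within the scatter. Ethoxycarbonyl therefore goes with weaker inhibition than either hydrogen or chloro at this place, although both steps are modest. No measurement at hand accounts for this shift.

On these data alone, whether the step goes with the ester itself or simply with a group of more heavy atoms stays open; a carboxylic acid, a methyl ester or a longer alkyl chain on the same carbon would separate the two. Also open, as far as these compounds go, is whether ethoxycarbonyl or chloro would behave alike on other carbons of this ring.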